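A few compounds are considered here, and "the series" means these few. Any claim that something is new, unique, unknown or untested is made for them only; others in the source may bear on it.

Within the data shown here, compound 1 `c1coc(-c2ccccc2NCC2=NCCN2)c1` is the only member of this small set with a number in a functional assay for activation of Alpha-1B adrenergic receptor (Homo sapiens), read by calcium flux; on this read-out lower numbers stand for an effect already at smaller amounts and higher numbers for an effect only at larger amounts of compound: compound 1 gives 6.31 nM. Compound 2 `Cc1ncc(-c2ccccc2NCC2=NCCN2)o1` carries 2-methyl-1,3-oxazol-5-yl in place of furan-2-yl on an aromatic carbon. In this assay compound 2 is reported only as a limit of the assay, < 5020 nM. Compound 3 `Cc1nc(-c2ccccc2NCC2=NCCN2)co1` carries 2-methyl-1,3-oxazol-4-yl in place of furan-2-yl on an aromatic carbon. For compound 3, this assay likewise reports a limit, < 5020 nM. The steps a step that the limit leaves unreadable from compound 1 to compound 2 and a step that the limit leaves unreadable from compound 1 to compound 3 are therefore unreadable, as is a step that the two limits leave unreadable from compound 2 to compound 3, because the limit of < 5020 nM in this assay, at which 2 of the 3 values shown sit, covers two of the three values. Compound 4 `Cc1cc(-c2ccccc2NCC2=NCCN2)on1` differs from compound 1 in one place: 3-methyl-1,2-oxazol-5-yl in place of furan-2-yl on an aromatic carbon. The measured steps that bear on this change, the exchange of furan-2-yl for a five-membered ring with two hetero atoms, give no readable size, so no direction can be drawn from them. Compound 4 is therefore expected to land near compound 1 with wide uncertainty, estimated as 20 nM with a range from 4 nM to 150 nM. That expectation corresponds to an expected step of a 3.2-fold higher number from compound 1 to compound 4 (0.50 log units; beyond the scatter).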

Compound 4, half-maximal effective concentration: 95.5 nM
Estimate against measurement, compound 4: 4.8-fold (0.68 log units) below; the range from low to high includes it.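

In this assay, the exchange of furan-2-yl for 3-methyl-1,2-oxazol-5-yl gives a 15-fold higher number from compound 1 to compound 4 (1.18 log units; beyond the scatter). Compound 4 is thus the first compound shown with a five-membered aromatic ring with 2 hetero atoms at this position to give a number, so such a ring can be compared directly with furan-2-yl here, and it costs a large step. The steps to compound 4 from compound 2 and from compound 3 still cannot be read, because those two compounds sit at the limit: the limit of < 5020 nM in this assay, at which 2 of the 4 values shown sit.

The compounds shown leave open how much of the step from furan-2-yl goes with the ring nitrogen and how much with the methyl group. They also leave open how an ethyl, a methoxy or an amine in place of that methyl would read.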